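The source may hold more compounds than are shown below. What is called first, only, known or untested is meant among the compounds shown, and "the series" means these compounds.

Measured so far in a functional assay on MCF7 cells (Homo sapiens) for inhibition, read by MTT assay, with a stated time of 72 h; a lower number here means a stronger inhibitor, a higher number a weaker inhibitor:
compound 1, `Cc1cc(Nc2cc(-c3ccccc3)[nH]n2)n2nc(SCc3ccc([N+](=O)[O-])cc3)nc2n1`, 5060 nM
compound 2, `Cc1cc(Nc2cc(C(C)(C)C)[nH]n2)n2nc(SCc3ccc(Br)cc3)nc2n1`, 7290 nM
compound 3, `Cc1cc(Nc2ccn(Cc3ccc(F)cc3)n2)n2nc(SCc3ccc(Br)cc3)nc2n1`, 4280 nM

Among these three, compound 1 holds the second highest of the three numbers. Its nearest neighbour is compound 3, whose value differs from it by an amount that lies within the scatter of the assay, and the furthest is compound 2, which also stays within that scatter. The three measured compounds therefore cannot be ordered against one another on these numbers alone; they share a core and differ in the groups attached to the sulfur and to the pyrazole.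

The unmeasured compound 4, `C=CCSc1nc2nc(C)cc(Nc3cc(-c4ccccc4)[nH]n3)n2n1`, departs from compound 1 by a single change:
vinyl in place of 4-nitrophenyl on a saturated chain carbon bound to a sulfur
Cut one bond further out, this reads as 4-nitrobenzyl to allyl on the sulfur. Going by the values given here, no pair of measured compounds shows a step of this kind, so its size is not known from the data. He expects the step of a 1.6-fold higher number from compound 1 to compound 4 (0.20 log units; within the scatter) to be small, toward a weaker inhibitor if anything, and possibly not beyond the scatter. For compound 4 he therefore estimates 8000 nM, with a range from 3000 nM to 25000 nM.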

Compound 4, half-maximal inhibitory concentration: > 50000 nM
Compound 4 gave a limit, no number; the forecaster's own chance of this, stated with the estimate: 15%; middle value at least 6.2-fold (0.79 log units) away from the limit.
By their numbers in this assay, from the lowest: compounds 3, 1 and 2 (each within the scatter of the next). At a limit, above all of these: compound 4.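

In this assay compound 4 gave > 50000 nM, which is a limit of the assay and not a number. Going by these compounds alone, exchanging 4-nitrobenzyl for allyl on the sulfur gives an at least 9.8-fold higher number from compound 1 to compound 4 (0.99 log units; beyond the scatter), the first step that can be read in one place, and it shows that the group on the sulfur is not indifferent, which the three earlier compounds, all within the scatter of one another and differing in more than one place, could not show. The true size of the step stays unknown, and only its lower bound is given: the limit of > 50000 nM in this assay, at which 1 of the 4 values shown sits.

The compounds shown leave open whether the aromatic ring of the 4-nitrobenzyl or its nitro group carries the difference, which a plain benzyl or a 4-bromobenzyl on the sulfur of compound 1 would separate. They also leave open whether a longer chain, such as butyl or hexyl, would behave like allyl.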